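The compounds below may be only part of what the source reports. "The series", "measured", "known", "first", "only" and "open" are said of these compounds alone.

Values so far in a functional assay on ACHN cells (Homo sapiens) for inhibition, read by colorimetric assay and sulforhodamine B assay, with a stated time of 48 h; on this read-out higher numbers stand for weaker inhibition of growth and lower numbers for stronger inhibition of growth

- compound 1 `CCCCCCCCCCCC[C@@H](O)[C@H]1CC[C@H]([C@H](O)CCCCCCCCCCNC(=O)c2cccs2)O1` gives 2570 nM here
- compound 2 `CCCCCCCCCCCC[C@@H](O)[C@H]1CC[C@H]([C@H](O)CCCCCCCCCCNC(=O)c2ccco2)O1` gives 100000 nM here

Within the data shown here, compound 2 stands at the higher end of the two, with 100000 nM as its value, and compound 1 is its only neighbour. Compound 3 `CCCCCCCCCCCC[C@@H](O)[C@H]1CC[C@H]([C@H](O)CCCCCCCCCCNC(=O)c2ccoc2)O1` carries furan-3-yl in place of furan-2-yl on a carbonyl carbon. Among the measured compounds shown here, the one measured step that bears on this is large (a 39-fold higher number from compound 1 to compound 2 (1.59 log units; beyond the scatter)), and it shows that exchanging the ring on this carbonyl carbon can shift the number strongly. For the measured compounds named here, no measured compound carries furan-3-yl, so the size of the next step remains open. A smaller step towards a lower number is expected (a 5.0-fold lower number from compound 2 to compound 3 (0.70 log units; beyond the scatter)), though none beyond the scatter would not surprise. Compound 3 is estimated at 20000 nM in this assay, with an expected range from 3000 nM to 100000 nM for now.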

Compound 3, concentration for 50% growth inhibition: 100000 nM
For compound 3 the middle estimate is 5.0-fold (0.70 log units) below the measured one; low and high end bracket the measured number.
By their numbers in this assay, from the lowest: compound 1; then compounds 2 and 3 (each within the scatter of the next).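

In this assay, furan-3-yl in place of furan-2-yl on the carbonyl carbon gives no separation (no change at the digits printed from compound 2 to compound 3 (within the scatter)), so the attachment point of the furan does not register at this read-out. The gap to the thiophen-2-yl amide therefore holds for both furans and is not peculiar to furan-2-yl (a 39-fold higher number from compound 1 to compound 3 (1.59 log units; beyond the scatter)). Nothing measured for these compounds accounts for the gap between the thiophen-2-yl amide and the two furan amides.

Open, from the compounds shown here alone, is whether thiophen-3-yl, phenyl or a pyridine ring on the same carbonyl carbon would stay with compound 1 or fall with compound 2 and compound 3. With a single sulfur-bearing ring in the set, it also remains unsettled whether the lower number belongs to thiophene generally or to the thiophen-2-yl form alone.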